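Swapping 4-Ethylphenyl for 3-Methylphenyl on a Shared Core

The source may hold more compounds than are shown below. What is called first, only, known or untested is meant among the compounds shown, and "the series" means these compounds.

Of the compounds shown here, three have been measured in a functional assay on KM12 cells (Homo sapiens) for inhibition, read by sulforhodamine B assay, with a stated time of 48 h, tested at 10 uM; a lower number here means less inhibition, a higher number more inhibition at the concentration tested (going by the name of the read-out). Compound 1 `COc1ccc(-c2cn3ccnc3c(-c3ccc4ncn(C5CCCCC5)c4c3)n2)cc1` gives 83.2%, compound 2 `FC(F)(F)c1cccc(-c2cn3ccnc3c(-c3ccc4ncn(C5CCCCC5)c4c3)n2)c1` gives 1.25%, and compound 3 `CCc1ccc(-c2cn3ccnc3c(-c3ccc4ncn(Cc5ccccc5)c4c3)n2)cc1` gives 45.7%. Compound 3 thus stands second highest of the three: compound 1 sits above it by a margin beyond the scatter, and compound 2 sits below it, also beyond the scatter.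

Compound 4 `Cc1cccc(-c2cn3ccnc3c(-c3ccc4ncn(Cc5ccccc5)c4c3)n2)c1` has not been measured yet. It arises from compound 3 by one change: 3-methylphenyl in place of 4-ethylphenyl on an aromatic carbon.

For the measured compounds named here, only one measured step touches the same place on the core, the exchange of 4-methoxyphenyl for 3-(trifluoromethyl)phenyl, which gave a number 82 percentage points lower from compound 1 to compound 2 (beyond the scatter). Going by the values given here, that step, like the one from compound 3 to compound 4, replaced a 4-substituted phenyl with a 3-substituted phenyl, yet the groups themselves were different, and compounds 1 and 2 differ from compounds 3 and 4 in another place as well, for which no step has been measured. Among the compounds with values here, with that large drop as the only guide, a decrease beyond the scatter is expected for compound 4, though a smaller one than the step from 1 to 2, since both groups exchanged here are simple alkyl groups. The step expected from compound 3 to compound 4 is a number 23.7 percentage points lower from compound 3 to compound 4 (beyond the scatter). In this assay compound 4 is estimated at 22%, within a range from 0% to 55%.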

Compound 4, a percentage reported as inhibition, at one concentration (the size of the read-out at that concentration, not a potency): 22.1%
For compound 4 the middle estimate is 0.1 percentage points below the measured one, within the range that was stated.
By their numbers in this assay, from the lowest: compound 2; then compound 4; then compound 3; then compound 1.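

In this assay, moving from 4-ethylphenyl to 3-methylphenyl gives a number 23.6 percentage points lower from compound 3 to compound 4 (beyond the scatter), so this position responds even to an exchange between two phenyl groups that carry only a small alkyl chain, with no hydrogen-bond donors or acceptors on either side. For the compounds shown here, the only earlier step at this position, a number 82 percentage points lower from compound 1 to compound 2 (beyond the scatter), exchanged 4-methoxyphenyl for 3-(trifluoromethyl)phenyl, so a fall beyond the scatter now also appears with a different pair of groups and on a different core, although it is a smaller fall. Nothing available here explains why either number falls.

The new step changes two things at once: the substituent moves to a different ring position and its chain becomes shorter, so the compounds shown cannot say which of the two matters, and a 4-methylphenyl or a 3-ethylphenyl group on the core of compound 3 would separate them. As far as these compounds go, it also remains open how this position would respond to a group of another kind, such as an aminophenyl or a carboxylic acid on the phenyl ring.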